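Swapping an Ester Chain for a Bromophenyl Acid

The source may hold more compounds than are shown below. What is called first, only, known or untested is meant among the compounds shown, and "the series" means these compounds.

Three vinyl sulfones have been measured in a functional assay on K562 cells (Homo sapiens) for cytotoxicity, read by trypan blue exclusion, with a stated time of 96 h; a lower number here means a stronger inhibitor, a higher number a weaker inhibitor. Compound 1 `COc1ccc(/C=C/S(=O)(=O)Cc2ccc(OC)c(N)c2)cc1` gives 2500 nM, compound 2 `COc1cc(OC)c(/C=C/S(=O)(=O)Cc2ccc(F)c([N+](=O)[O-])c2)c(OC)c1` gives 25000 nM, and compound 3 `COC(=O)CCNc1cc(CS(=O)(=O)/C=C/c2c(OC)cc(OC)cc2OC)ccc1OC` gives 1000 nM. Compound 3 stands lowest of the three; its gap to compound 1 lies beyond the scatter, and its gap to compound 2 lies well beyond it. Within the data shown here, none of these three differs from another in a single place, so no clean step between measured compounds can be read off.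

Compound 4 `COc1cc(OC)c(/C=C/S(=O)(=O)Cc2ccc(OC)c(NC(C(=O)O)c3ccc(Br)cc3)c2)c(OC)c1` keeps the core of compound 3 and changes only the group on the ring nitrogen: (4-bromophenyl)(carboxy)methyl in place of 2-(methoxycarbonyl)ethyl on a nitrogen on an aromatic ring. The incoming group is larger and carries a free carboxylic acid and a bromine-bearing aromatic ring in place of a methyl ester.

Among the measured compounds shown here, nothing among the measured compounds tells how such an acid-bearing group behaves in this assay, so the expectation rests on compound 3 alone. A step of modest size toward a weaker inhibitor is expected from compound 3 to compound 4 in this assay, a 2.0-fold higher number from compound 3 to compound 4 (0.30 log units; within the scatter), with a wide range in either direction. Compound 4 is estimated at 2000 nM, between 500 nM and 8000 nM.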

Compound 4, half-maximal inhibitory concentration: 200 nM
Estimate against measurement, compound 4: 10-fold (1.00 log units) above, outside the stated range (below it).
By their numbers in this assay, from the lowest: compound 4; then compound 3; then compound 1; then compound 2.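

In this assay, the nitrogen on an aromatic ring accepts a far bulkier substituent than compound 3 alone could show: (4-bromophenyl)(carboxy)methyl in place of 2-(methoxycarbonyl)ethyl gives a 5.0-fold lower number from compound 3 to compound 4 (0.70 log units; beyond the scatter), a step beyond the scatter. The position therefore does not depend on keeping a ring-free ester chain, since a group with more heavy atoms, a six-membered aromatic ring and a free carboxylic acid goes with a lower number on the same core. No measurement shown here accounts for this gain in this assay, so the step stands as an observation without an explanation.

Because the entering group differs from the leaving one in several ways at once, the data cannot say whether the bromine, the aromatic ring or the carboxylic acid carries the step. The methyl ester of this same acid, a plain phenyl or 4-chlorophenyl group in place of the 4-bromophenyl group, and a simple acetic acid chain on the nitrogen would each separate one of these parts from the others.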